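The source may hold more compounds than are shown below. What is called first, only, known or untested is meant among the compounds shown, and "the series" means these compounds.

Of the compounds shown here, three carry a measured value so far. Compound 1 `O/N=C1/C(c2c[nH]c3ccc(OCc4ccccc4)cc23)=Nc2ccc(OCc3ccccc3)cc21` gives 14500 nM in a functional assay on MGC-803 cells (Homo sapiens) for cytotoxicity, read by MTT assay, with a stated time of 2 days; a higher number here means a weaker inhibitor, a lower number a stronger inhibitor. Compound 2 `Cc1ccc(CO/N=C2/C(c3c[nH]c4ccccc34)=Nc3ccccc32)cc1` gives 22800 nM in this assay, the highest of the three numbers; compound 1 lies within the scatter of it, while compound 3 `FC(F)(F)c1ccc(CO/N=C2/C(c3c[nH]c4ccc(Br)cc34)=Nc3ccc(Br)cc32)cc1` gives 11100 nM, a gap beyond the scatter. Compound 4 `Fc1ccc(CO/N=C2/C(c3c[nH]c4ccccc34)=Nc3ccccc32)c(Cl)c1` has not yet been measured in this assay. It differs from compound 2 by 2-chloro-4-fluorophenyl in place of 4-methylphenyl on a saturated chain carbon bound to an oxygen on an unsaturated carbon. Within the data shown here, no measured pair in the set shows this change alone, so only a small step is expected for compound 4, estimated as a 1.5-fold lower number from compound 2 to compound 4 (0.18 log units; within the scatter), a shift toward a lower number but likely not beyond the scatter. Compound 4 is thus estimated at 15000 nM, within the range 6000 nM to 45000 nM.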

Compound 4, half-maximal inhibitory concentration: 18500 nM
Compound 4: the middle estimate sits 1.2-fold (0.09 log units) below what was measured; the measured number falls inside the stated range.
By their numbers in this assay, from the lowest: compounds 3, 1, 4 and 2 (each within the scatter of the next, the first and the last beyond it).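

In this assay, among these compounds, 2-chloro-4-fluorophenyl in place of 4-methylphenyl on a saturated chain carbon bound to an oxygen on an unsaturated carbon gives a 1.2-fold lower number from compound 2 to compound 4 (0.09 log units; within the scatter), the first single-place step. At this position, therefore, exchanging one substituted phenyl for the other produces no change that can be read beyond the scatter. Nothing available bears on the reason for this result.

Open, going by these compounds, is whether an amine or a carboxylic acid on this phenyl ring, or a longer chain in place of the benzyl group, would give a step beyond the scatter. Also open, on these data alone, is whether the same change behaves alike on the core of compound 3.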